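Sulfonamide variation in a kinase inhibitor series

A few compounds are considered here, and "the series" means these few. Any claim that something is new, unique, unknown or untested is made for them only; others in the source may bear on it.

Two measured compounds share a core and differ in two places. Compound 1 `CN1C(=O)C(c2c(F)cccc2F)N(C)c2nc(Nc3ccc(S(=O)(=O)N(C)C)cc3)ncc21` carries a dimethylsulfamoyl group on the aniline ring and a difluorophenyl substituent; in an assay on Sf9 cells for inhibition of serine/threonine-protein kinase 4 (Homo sapiens), read by luminescence and ADP-Glo, with a stated time of 1 h, in the presence of a further agent that is not named here (a lower number here means a stronger inhibitor, a higher number a weaker inhibitor), compound 1 gives 181 nM. Compound 2 `CCNS(=O)(=O)c1ccc(Nc2ncc3c(n2)N(C)C(c2ccccc2C)C(=O)N3C)cc1` carries an ethylsulfamoyl group and a methylphenyl substituent; in this assay compound 2 gives 119 nM, the lowest of the two numbers, with compound 1 as its nearest neighbour at a gap that sits within the scatter. Among the measured compounds shown here, no pair differing in one place only has been measured, so no single-point step is known.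

Compound 3 `Cc1ccccc1C1C(=O)N(C)c2cnc(Nc3ccc(S(=O)(=O)N(C)C)cc3)nc2N1C` is the unmeasured hybrid: it keeps the methylphenyl substituent of compound 2 and takes the sulfonamide of compound 1. The change from compound 2 is dimethylamino in place of ethylamino on a sulfonyl sulfur. Since compound 1 and compound 2 read within the scatter of each other despite two differences, the isolated sulfonamide change is expected to give little beyond the scatter, in no firm direction; the expected step is a 1.3-fold higher number from compound 2 to compound 3 (0.10 log units; within the scatter). Compound 3 is therefore estimated at 150 nM in this assay, with a range from 60 nM to 400 nM.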

Compound 3, half-maximal inhibitory concentration: 219 nM
For compound 3 the middle estimate is 1.5-fold (0.16 log units) below the measured one, within the range that was stated.
By their numbers in this assay, from the lowest: compounds 2, 1 and 3 (each within the scatter of the next).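

Compound 3 resolves the two differences between compound 1 and compound 2 into single changes, each read in this assay. Dimethylamino in place of ethylamino on a sulfonyl sulfur gives a 1.8-fold higher number from compound 2 to compound 3 (0.26 log units; within the scatter) and thus stays within the scatter, even though ethylamino carries a hydrogen-bond donor and dimethylamino carries none; 2-methylphenyl in place of 2,6-difluorophenyl on a saturated ring carbon gives a 1.2-fold higher number from compound 1 to compound 3 (0.08 log units; within the scatter) and also stays within the scatter. Neither place therefore shows a resolved difference for these particular groups, and no information is available on what sets the size of either step.

Going by these compounds, it remains open whether a group of a different kind on the sulfonyl sulfur, such as a longer chain ending in an amine or a carboxylic acid, would give a step beyond the scatter. On these data alone, it is equally open whether an unsubstituted phenyl or a larger ring on the saturated ring carbon would separate from the 2-methylphenyl and 2,6-difluorophenyl groups, and whether changes at the two places combine independently.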